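Swapping a Fluorophenyl for an Oxadiazole: Expected Cell Toxicity

The source may hold more compounds than are shown below. What is called first, only, known or untested is meant among the compounds shown, and "the series" means these compounds.

Compound 1, `O=C1CC(c2ccc(F)cc2)CN1c1cnn2c1CN(C(=O)Nc1cc(F)c(F)c(F)c1)C(C1CC1)C2`, carries a 4-fluorophenyl on a saturated ring carbon of its five-membered ring. For the measured compounds named here, in a toxicity assay on HepG2 2.2.15 cells (Homo sapiens) for cytotoxicity, read by CellTiter-Glo (on this read-out lower numbers stand for higher toxicity in this test and higher numbers for lower toxicity in this test), compound 1 gives 32100 nM, the only outright number among the three compounds measured. Compound 2, `O=C1CC(c2ccccc2)CN1c1cnn2c1CN(C(=O)Nc1cc(F)c(F)c(F)c1)C(Cc1ccccc1)C2`, returns only a limit of the assay in this assay, namely > 2000 nM. Compound 3, `O=C(Nc1cc(F)c(F)c(F)c1)N1CCCn2ncc(N3CC(c4ccccc4)CC3=O)c2C1`, likewise stops at a limit in this assay, > 2000 nM. Going by the values given here, two of the three values therefore sit at the limit of > 2000 nM in this assay, at which 2 of the 3 values shown sit, so no step between measured compounds can be sized, and the number for compound 1 is the sole anchor.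

Compound 4, `Cc1nc(C2CC(=O)N(c3cnn4c3CN(C(=O)Nc3cc(F)c(F)c(F)c3)C(C3CC3)C4)C2)no1`, differs from compound 1 in a single place: 5-methyl-1,2,4-oxadiazol-3-yl in place of 4-fluorophenyl on a saturated ring carbon. A 5-methyl-1,2,4-oxadiazol-3-yl stands where the 4-fluorophenyl stood, on a saturated ring carbon; the rest of the shared core is unchanged.

Among the compounds with values here, with no measured step to lean on, the expected step is a 1.1-fold lower number from compound 1 to compound 4 (0.03 log units; within the scatter), none beyond the usual scatter in this assay. Compound 4 is thus estimated at 30000 nM, with a range from 10000 nM to 100000 nM.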

Compound 4, half-maximal cytotoxic concentration: > 200000 nM
Compound 4 gave a limit, no number; the forecaster's own chance of this, stated with the estimate: 35%; at least 6.6-fold (0.82 log units) between middle value and limit.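

In this assay compound 4 gives > 200000 nM, which is a limit of the assay and not a number. Even so, placing 5-methyl-1,2,4-oxadiazol-3-yl in place of 4-fluorophenyl on this saturated ring carbon yields a step beyond the scatter, an at least 6.2-fold higher number from compound 1 to compound 4 (0.79 log units; beyond the scatter), and a higher number here stands for lower toxicity in this test. The earlier compounds shown here offered no step at all, so only now is there a sign that the group at this place can shift the read-out.

The full size of the step stays unknown because compound 4 sits at a limit: the limit of > 200000 nM in this assay, at which 1 of the 4 values shown sits. The compounds shown also leave open how far this shift belongs to the oxadiazole ring or to its methyl, and how an amine or a carboxylic acid on the same ring carbon would read.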